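The source may report more compounds than this note shows. Statements on the series, on what has been measured and on what is new or still open speak of the compounds shown alone.

Measured so far:
compound 1 `O=C(COc1ccc(CNC2CC=C(c3c[nH]c4cccc(F)c34)CC2)c(F)c1)NO` — 173 nM
compound 2 `O=C(COc1ccc(CNC2CC=C(c3c[nH]c4ccc(F)cc34)CC2)c(F)c1)NO` — 261 nM
compound 3 `O=C(COc1ccc(C(=O)N2CC=C(c3c[nH]c4ccc(F)cc34)CC2)cc1)NO` — > 5000 nM

In a functional assay on HCT-116 cells (Homo sapiens) for antiproliferative activity, with a stated time of 72 h (a higher number here means a weaker inhibitor, a lower number a stronger inhibitor), compound 2 gives 261 nM and compound 1 gives 173 nM. The change between them, (4-fluoro-1H-indol-3-yl in place of 5-fluoro-1H-indol-3-yl on a double-bonded ring carbon), gives a 1.5-fold lower number from compound 2 to compound 1 (0.18 log units; within the scatter). Compound 3 in this assay gives only a limit, > 5000 nM, not a number; this is the limit of > 5000 nM in this assay, at which 1 of the 3 values shown sits. The difference between the core of compound 2 and the core of compound 3 is not broken down here.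

Compound 4 `O=C(COc1ccc(C(=O)N2CC=C(c3c[nH]c4cccc(F)c34)CC2)cc1)NO` is not yet measured. It differs from compound 3 by 4-fluoro-1H-indol-3-yl in place of 5-fluoro-1H-indol-3-yl on a double-bonded ring carbon. This is the same kind of change as from compound 2 to compound 1, not the same: the ring bearing the change is there of carbon only, whereas here it holds one nitrogen, three ring bonds from the ring nitrogen. The step that the limit leaves unreadable from compound 3 to compound 4 is expected to be small, resting on a 1.5-fold lower number from compound 2 to compound 1 (0.18 log units; within the scatter). Compound 4 is estimated at 7000 nM, between 2500 nM and 20000 nM, most likely again reported only as a limit.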

Compound 4, half-maximal inhibitory concentration: 1410 nM
Compound 4: middle estimate off by 5.0-fold (0.70 log units), on the high side, outside the stated range (below it).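

In this assay the exchange gives an at least 3.5-fold lower number from compound 3 to compound 4 (0.54 log units; beyond the scatter), so on the core of compound 3 the 4-fluoro-1H-indol-3-yl group gives a lower number than the 5-fluoro-1H-indol-3-yl group. Compound 3 is held only as a limit, > 5000 nM, so the full size of this step is not known. Set beside the same change on the other core, the result shows no settled difference between the cores: the same change on two cores in this assay, a 1.5-fold lower number (0.18 log units; within the scatter) from compound 2 to compound 1 and an at least 3.5-fold lower number (0.54 log units; beyond the scatter) from compound 3 to compound 4; the limit leaves it open whether they differ

With only two cores shown, no rule for carrying this change across the series follows. From the compounds shown here alone, it stays open whether a chlorine or a methoxy group in place of the fluorine, or a longer chain in place of the one bearing the hydroxamic acid, would behave alike on both cores.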